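A Hydroxy Group Added to Compound 1

The source may report more compounds than this note shows. Statements on the series, on what has been measured and on what is new or still open speak of the compounds shown alone.

In a functional assay on A549 cells (Homo sapiens) for cytotoxicity, read by sulforhodamine B assay, with a stated time of 72 h (on this read-out lower numbers stand for stronger inhibition of growth and higher numbers for weaker inhibition of growth), compound 1 `C=C1CC[C@@H]2[C@](C)(CCC[C@]2(C)C(=O)OC)[C@H]1CCc1ccc2c(OC)ccc(OC)c2c1` gives > 6700 nM, which is a limit of the assay and not a number. Compound 2 `C=C1CC[C@@H]2[C@](C)(CCC[C@]2(C)C(=O)OC)[C@H]1CCc1ccc2c(OCc3ccccc3)ccc(OCc3ccccc3)c2c1` gives > 5000 nM, which is likewise only a limit. With no number on either side, the two compounds cannot be ranked, and compound 1 has no measured position beyond its limit.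

Compound 3 `C=C1[C@H](O)C[C@@H]2[C@](C)(CCC[C@]2(C)C(=O)OC)[C@H]1CCc1ccc2c(OC)ccc(OC)c2c1` departs from compound 1 in one place, with hydroxy in place of hydrogen on a saturated ring carbon. For the measured compounds named here, no measured pair shows what a single change does on the shared core, so the expectation has little to rest on. It leans first on compound 1, whose limit is > 6700 nM. It leans also on compound 2, whose limit is > 5000 nM.

In this assay the expected step that the limit leaves unreadable from compound 1 to compound 3 is no larger than the scatter, and no direction is expected. Compound 3 may well return only a limit too. For compound 3 the estimated concentration for half-maximal growth inhibition is 7000 nM, within an expected range of 2500 nM to 20000 nM.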

Compound 3, concentration for 50% growth inhibition: > 6400 nM
Compound 3: a limit, no number; the forecaster's own chance of this, stated with the estimate: 60%; the middle value does not contradict the limit.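

In this assay, compound 3 returns only a limit of the assay, as compound 1 does, so the step between compound 1 and compound 3, hydroxy in place of hydrogen on a saturated ring carbon, cannot be read. The compounds shown leave open whether any change on the shared core yields a measurable value in this assay rather than a limit.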